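The source may hold more compounds than are shown below. What is called first, only, known or untested is meant among the compounds shown, and "the series" means these compounds.

In a functional assay on HCT-116 cells (Homo sapiens) for antiproliferative activity, read by MTT assay, with a stated time of 72 h (on this read-out lower numbers stand for stronger inhibition and higher numbers for weaker inhibition), three compounds that share one core have been measured. Compound 1 `Nc1nc(N)c2cc(CSC(=S)N3CCN(C4CCCCC4)CC3)ccc2n1` gives 8400 nM, compound 2 `Nc1nc(N)c2cc(CSC(=S)N3CCN(c4ccc(F)cc4F)CC3)ccc2n1` gives 5150 nM, and compound 3 `Nc1nc(N)c2cc(CSC(=S)N3CCN(c4ccccc4[N+](=O)[O-])CC3)ccc2n1` gives 5520 nM. Compound 3 cannot be ranked against the other two, as the steps of a 1.5-fold lower number from compound 1 to compound 3 (0.18 log units; within the scatter) and a 1.1-fold higher number from compound 2 to compound 3 (0.03 log units; within the scatter) both lie within the scatter.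

The next compound is compound 4 `Nc1nc(N)c2cc(CSC(=S)N3CCN(c4ccccn4)CC3)ccc2n1`, which has pyridin-2-yl in place of 2-nitrophenyl on an amine nitrogen in a ring. The measured steps that bear on this change are exchanges at that same place. Besides the two already given, there is the step of a 1.6-fold lower number from compound 1 to compound 2 (0.21 log units; within the scatter), which also lies within the scatter. None of these steps involves pyridin-2-yl, so the data give no direct reading of that group. Even so, no exchange at this place has yet moved the number beyond the scatter, and none is expected here in this assay.

The expected change is a step of a 1.0-fold lower number from compound 3 to compound 4 (0.00 log units; within the scatter). The estimate for compound 4 is 5500 nM, with an expected range from 2800 nM to 11000 nM.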

Compound 4, half-maximal inhibitory concentration: 5960 nM
For compound 4 the middle estimate is 1.1-fold (0.03 log units) below the measured one; the range from low to high includes it.
By their numbers in this assay, from the lowest: compounds 2, 3, 4 and 1 (each within the scatter of the next).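

In this assay, pyridin-2-yl brings the first aromatic ring with a hetero atom to this place on the amine nitrogen in a ring, and it has fewer heavy atoms than the 2-nitrophenyl it replaces, yet the number stays within the scatter (a 1.1-fold higher number from compound 3 to compound 4 (0.03 log units; within the scatter)). The same holds against the two other groups (a 1.2-fold higher number from compound 2 to compound 4 (0.06 log units; within the scatter); a 1.4-fold lower number from compound 1 to compound 4 (0.15 log units; within the scatter)), so all four compounds remain unranked, and neither a hetero atom in the aromatic ring nor the loss of the nitro group has shifted the number beyond the scatter. The data offer no measurement that would account for this flat result.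

Going by these compounds, whether a benzyl group, an acetyl group or a chain ending in a carboxylic acid at this nitrogen would move the number beyond the scatter stays open. So does whether changes elsewhere on the shared core would do so.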